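The source may hold more compounds than are shown below. What is called first, only, known or untested is meant among the compounds shown, and "the series" means these compounds.

Of the compounds shown here, two have so far been measured in a functional assay on CHO cells for antagonist activity at sphingosine 1-phosphate receptor 2 (Homo sapiens), read by GTPgammaS binding; on this read-out lower numbers stand for stronger inhibition and higher numbers for weaker inhibition. Compound 1 `O=C(O)Cn1nc(Cc2nc3cc(Cl)c(OCC(F)F)cc3[nH]2)c2ccccc2c1=O` gives 15 nM. Compound 2 `CCC(C(=O)O)c1nn(Cc2cn3cc(OCC4CC4)c(Cl)cc3n2)c2ccccc2c1=O` gives 43 nM, the higher of the two numbers; compound 1 sits lower by a gap beyond the usual scatter. Compound 3 `COC(C(=O)O)c1nn(Cc2cn3cc(OCC4CC4)c(Cl)cc3n2)c2ccccc2c1=O` has not yet been measured. It differs from compound 2 in one place: methoxy in place of ethyl on a saturated chain carbon bound to an aromatic carbon and a carbonyl carbon. Within the data shown here, no measured pair shows this kind of change, so only a modest step is expected, a 1.2-fold higher number from compound 2 to compound 3 (0.07 log units; within the scatter), most likely none beyond the scatter. Compound 3 is accordingly estimated at 50 nM, within a range from 20 nM to 130 nM.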

Compound 3, half-maximal inhibitory concentration: 58 nM
Estimate against measurement, compound 3: 1.2-fold (0.06 log units) below, and the stated range covers the measured number.
By their numbers in this assay, from the lowest: compound 1; then compounds 2 and 3 (each within the scatter of the next).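

In this assay, methoxy in place of ethyl on this saturated chain carbon gives a 1.3-fold higher number from compound 2 to compound 3 (0.13 log units; within the scatter). This first reading at the position shows that a chain of the same heavy-atom count, now holding an oxygen and a hydrogen-bond acceptor, leaves the number within the scatter. Nothing measured here explains why the two groups read alike. From the compounds shown here alone, whether a longer chain, a hydroxyl or an amine on that same carbon would also leave the number within the scatter stays open. So does whether this swap would read the same on another core.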